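Exchanging trifluoromethyl for a sulfonylamino group on the aryl ring

The source may report more compounds than this note shows. Statements on the series, on what has been measured and on what is new or still open speak of the compounds shown alone.

Compound 1 `COc1ccc([C@H]2CC(=O)N(c3cccc(C(F)(F)F)c3)C2)cc1OC1CCCC1` was tested in a functional assay on HEK293 cells (Homo sapiens) for cytotoxicity; on this read-out lower numbers stand for higher toxicity in this test and higher numbers for lower toxicity in this test. In this assay compound 1 gives > 10000 nM, which is a limit of the assay rather than a number. Compound 2 `COc1ccc([C@H]2CC(=O)N(c3ccc(S(C)(=O)=O)cc3)C2)cc1OC1CCCC1` carries 4-(methylsulfonyl)phenyl in place of 3-(trifluoromethyl)phenyl on an amide-type nitrogen in a ring. In this assay compound 2 gives > 10000 nM, again a limit. The step that the two limits leave unreadable from compound 1 to compound 2 therefore cannot be read. Both values sit at the limit of > 10000 nM in this assay, at which 2 of the 2 values shown sit, so compound 1 stands at the limit shared by every measurement shown, and no compound can be ordered against another.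

Compound 3 `COc1ccc([C@H]2CC(=O)N(c3cccc(NS(=O)(=O)c4cccc(F)c4)c3)C2)cc1OC1CCCC1` is not yet measured. It differs from compound 1 by ((3-fluorophenyl)sulfonyl)amino in place of trifluoromethyl on an aromatic carbon. No measured step bears on this change; the only step shown, from compound 1 to compound 2, is unreadable in size and concerns another change. With both shown values resting at the limit, compound 3 is expected to stay at the limit as well, and the expected step of a number no higher from compound 1 to compound 3 (the limit leaves the size open) is none beyond the scatter. Compound 3 is estimated at 10000 nM, within 5000 nM to 40000 nM.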

Compound 3, half-maximal cytotoxic concentration: > 10000 nM
Compound 3 gave a limit, no number (the forecaster's own chance of this, stated with the estimate: 85%); the middle value lies on the limit itself.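

No step can be read from compound 1 to compound 3, as both values are limits of the assay and not numbers: the limit of > 10000 nM in this assay, at which 3 of the 3 values shown sit.

The compounds shown leave open whether trifluoromethyl, 4-(methylsulfonyl)phenyl or ((3-fluorophenyl)sulfonyl)amino makes any difference in this assay, and at what concentration compound 1, compound 2 or compound 3 would become cytotoxic.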